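Second Chloro on the Core: Estimating Compound 4

A few compounds are considered here, and "the series" means these few. Any claim that something is new, unique, unknown or untested is made for them only; others in the source may bear on it.

In a functional assay on HCT-116 cells (Homo sapiens) for cytotoxicity, read by sulforhodamine B assay, with a stated time of 48 h (on this read-out lower numbers stand for stronger inhibition of growth and higher numbers for weaker inhibition of growth), three compounds have been measured:
compound 1 `ClCc1cccc(Cn2cnc3ncnc(Cl)c32)c1` gives 1770 nM
compound 2 `ClCc1ccccc1Cn1cnc2ncnc(Cl)c21` gives 1510 nM
compound 3 `ClCc1cccc(Cn2cnc3nc(Cl)nc(Cl)c32)c1` gives 750 nM

Compound 1 and compound 2 are built from the same atoms joined differently; the difference between the two cores is not broken down here. Compound 3 arises from compound 1 by chloro in place of hydrogen on an aromatic carbon, and in this assay that single step was a 2.4-fold lower number from compound 1 to compound 3 (0.37 log units; beyond the scatter). Compound 4 `ClCc1ccccc1Cn1cnc2nc(Cl)nc(Cl)c21` is not yet measured; it arises from compound 2 by the same change, (chloro in place of hydrogen on an aromatic carbon), at a place described in identical words. Within the data shown here, because the one earlier example of this change is a 2.4-fold lower number from compound 1 to compound 3 (0.37 log units; beyond the scatter), and compound 2 starts from 1510 nM, the expected step is a 2.3-fold lower number from compound 2 to compound 4 (0.37 log units; beyond the scatter). One example is a thin basis, so the range is kept wide. Compound 4 is therefore estimated at 650 nM, between 350 nM and 1200 nM.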

Compound 4, concentration for 50% growth inhibition: 1860 nM
The estimate for compound 4 lay 2.9-fold (0.46 log units) below the measured number; measured number outside the range, above it.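

In this assay, chloro in place of hydrogen on an aromatic carbon gave a 1.2-fold higher number from compound 2 to compound 4 (0.09 log units; within the scatter), so the drop in the number seen on the core of compound 1 did not carry over to the core of compound 2. The two results do not agree, and the outcome of this change differs with the core that carries it: the same change on two cores in this assay, a 2.4-fold lower number (0.37 log units; beyond the scatter) from compound 1 to compound 3 and a 1.2-fold higher number (0.09 log units; within the scatter) from compound 2 to compound 4, 2.9-fold (0.46 log units) apart, beyond the scatter of two such steps

In this series, then, a step measured on one core cannot simply be added to another, though two examples do not show why the cores differ or how a further core would respond.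

The compounds shown carry only hydrogen or chloro at this place between two ring nitrogen atoms, so an amine or a methoxy group there remains open. Whether either would behave alike on both cores is open too.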